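Benzamide in place of hydroxamate on a shared core

The source may hold more compounds than are shown below. What is called first, only, known or untested is meant among the compounds shown, and "the series" means these compounds.

Measured so far in an assay on isolated protein for inhibition of protein deacetylase HDAC6 (Homo sapiens), with a stated time of 15 min; a higher number here means a weaker inhibitor, a lower number a stronger inhibitor:
compound 1 `Nc1nc(NCc2ccc(C(=O)NO)cc2)nc2nc(-c3ccco3)nn12` gives 3 nM
compound 2 `Nc1nc(NCCCc2ccc(C(=O)NO)cc2)nc2nc(-c3ccco3)nn12` gives 4.9 nM
compound 3 `Nc1nc(NCCCCCCC(=O)NO)nc2nc(-c3ccco3)nn12` gives 10.6 nM

Compound 1 carries the lowest number of the three in this assay. The gap to compound 2 lies within the usual scatter, so the two cannot be told apart on these numbers. Compound 3, with its seven-carbon chain in place of the benzylic link, lies beyond the scatter and is the weaker of the pair; the three share the core shown in their structures and differ only in the linker between it and the hydroxamic acid.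

Compound 4 `Nc1ccccc1NC(=O)c1ccc(CNc2nc(N)n3nc(-c4ccco4)nc3n2)cc1` is not yet measured. It keeps the linker and core of compound 1 and changes the warhead: 2-aminophenyl in place of hydroxy on an amide-type nitrogen. For the measured compounds named here, no pair among the measured compounds makes this kind of exchange, so no measured step can be carried over. The expectation rests on the general run of such exchanges on this target class, where the anilide leaves the number much higher. The step from compound 1 to compound 4 is expected to be large, upward, well beyond the scatter, at a 1000-fold higher number from compound 1 to compound 4 (3.00 log units; beyond the scatter). Compound 4 is expected to give about 3000 nM in this assay, most likely between 300 nM and 30000 nM, with a real chance that only a limit is reported.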

Compound 4, half-maximal inhibitory concentration: > 10000 nM
Compound 4 ended at the assay's limit; the forecaster's own chance of this, stated with the estimate: 30%; middle value at least 3.3-fold (0.52 log units) away from the limit.
By their numbers in this assay, from the lowest: compounds 1 and 2 (each within the scatter of the next); then compound 3. At a limit, above all of these: compound 4.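

In this assay, for the compounds shown here, compound 4 gives > 10000 nM, a limit of the assay and not a number, and it is the only such value in the set: the limit of > 10000 nM in this assay, at which 1 of the 4 values shown sits. With linker and shared core unchanged, 2-aminophenyl in place of hydroxy on an amide-type nitrogen gives an at least 3300-fold higher number from compound 1 to compound 4 (3.52 log units; beyond the scatter), and since this rests on a limit, the true size of the step cannot be read. Compounds 1, 2 and 3 all keep the hydroxamic acid and differ only in the linker, so this is the first change shown at the hydroxycarbamoyl end, and the number moves far more here than the values of those three differ from one another.

Still open, from the compounds shown here alone, is how a carboxylic acid or a simple primary amide would read at this place. Also open, going by these compounds, is whether (2-aminophenyl)carbamoyl gives the same outcome on the linkers of compound 2 and compound 3.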